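The source may report more compounds than this note shows. Statements on the series, on what has been measured and on what is new or still open speak of the compounds shown alone.

The shared core of this small set is seen in compound 1 `Nc1cc(N)c2nc(-c3ccccc3)c(Oc3ccc(Cl)c(Cl)c3)nc2c1`, which carries a 3,4-dichlorophenoxy group on the core. In a functional assay on A549 cells (Homo sapiens) for inhibition, read by sulforhodamine B assay, with a stated time of 48 h (a lower number here means a stronger inhibitor of growth, a higher number a weaker inhibitor of growth), compound 1 gives 43700 nM. Compound 2 `Nc1cc(N)c2nc(-c3ccccc3)c(NCc3ccc(Cl)c(Cl)c3)nc2c1` is a close relative with a different linker to the same dichlorinated ring. In this assay compound 2 gives 27500 nM, and the two numbers lie within the scatter of each other, so neither compound can be called the stronger one. Compound 3 `CCOC(=O)[C@H](CCC(=O)O)NC(=O)c1ccc(Sc2nc3cc(N)cc(N)c3nc2-c2ccccc2)cc1` is reported only as a limit of the assay, < 100000 nM, and not as a number (the limit of < 100000 nM in this assay, at which 1 of the 3 values shown sits).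

Compound 4 `Nc1cc(N)c2nc(-c3ccccc3)c(Oc3ccc(F)cc3)nc2c1` has not yet been measured. It differs from compound 1 in one place: 4-fluorophenyl in place of 3,4-dichlorophenyl on an oxygen on an aromatic ring. Within the data shown here, no measured pair in this set shows what such a change does, so the expectation rests on the two numbers alone. The step from compound 1 to compound 4 is expected to be a 1.4-fold higher number from compound 1 to compound 4 (0.14 log units; within the scatter), a modest shift toward a higher number that may well stay within the scatter. Compound 4 is therefore estimated at 60000 nM in this assay, with a range from 20000 nM to 150000 nM.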

Compound 4, concentration for total growth inhibition: 46800 nM
The estimate for compound 4 lay 1.3-fold (0.11 log units) above the measured number; low and high end bracket the measured number.
By their numbers in this assay, from the lowest: compounds 2, 1 and 4 (each within the scatter of the next).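

In this assay, the two chlorines of the 3,4-dichlorophenyl group give way to the single fluorine of the 4-fluorophenyl group, and the result is a 1.1-fold higher number from compound 1 to compound 4 (0.03 log units; within the scatter). Among these compounds, this is the first step in the set that can be read at this position, and it shows that compound 1 and compound 4 cannot be told apart, even though the halogens differ in kind, in number and in where they sit on the ring. Nothing measured here explains why the two compounds read alike.

A single step cannot show whether this position tolerates every group or only these two halogenated rings. Going by these compounds, it remains open how a plain phenyl, or a phenyl carrying an amine or a carboxylic acid, would read on the same oxygen.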